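Cyclising the amine of compound 1: an expectation

A few compounds are considered here, and "the series" means these few. Any claim that something is new, unique, unknown or untested is made for them only; others in the source may bear on it.

Measured so far:
compound 1, `CCN(CC)c1ccc(C(=O)N2CCCCc3ccccc32)c(Cl)c1`, 19 nM
compound 2, `CN(C)c1ccc(C(=O)N2CCCCc3cc(Cl)ccc32)c(Cl)c1`, 13 nM

Two compounds share a core and have been run in an assay on HeLa cells for binding affinity to Vasopressin V2 receptor (Homo sapiens); a lower number here means a stronger inhibitor, a higher number a weaker inhibitor. Compound 1, with the structure `CCN(CC)c1ccc(C(=O)N2CCCCc3ccccc32)c(Cl)c1`, gives 19 nM in this assay. Compound 2, `CN(C)c1ccc(C(=O)N2CCCCc3cc(Cl)ccc32)c(Cl)c1`, gives 13 nM. Compound 1 holds the top number of the two, but the gap to compound 2 is within the scatter of repeated measurements, so the pair cannot be told apart on these data. For the measured compounds named here, the two also differ in more than one place, so no single step between them can be read.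

Compound 3, `CC1CCN(c2ccc(C(=O)N3CCCCc4ccccc43)c(Cl)c2)C1`, has not yet been measured. It differs from compound 1 in one place: 3-methylpyrrolidin-1-yl in place of diethylamino on an aromatic carbon. An open chain becomes a ring of similar size, with the same count of donors and acceptors and no change in charge. Going by the values given here, with no measured step of this kind to lean on, the expected step from compound 1 to compound 3 is none beyond the scatter, a 1.2-fold lower number from compound 1 to compound 3 (0.07 log units; within the scatter). The estimate for compound 3 in this assay is 16 nM, within a range of 5 nM to 50 nM.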

Compound 3, half-maximal inhibitory concentration: 51 nM
Compound 3: the middle estimate sits 3.2-fold (0.50 log units) below what was measured, and the stated range ends below it.
By their numbers in this assay, from the lowest: compounds 2 and 1 (each within the scatter of the next); then compound 3.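

In this assay replacing the open-chain diethylamino group with the ring of 3-methylpyrrolidin-1-yl gives a 2.7-fold higher number from compound 1 to compound 3 (0.43 log units; beyond the scatter) and so shows that this aromatic carbon, para to a large group and meta to a chloro group, responds to the amine it carries, something the earlier pair could not show because its members differ in more than one place. For the compounds shown here, the hydrogen-bond donor and acceptor counts and the net charge stay the same across this change, so those counts alone do not settle the outcome here, while the single step cannot separate the new ring from the added methyl group. Nothing measured here bears on why the number rose.

The compounds shown leave open whether the ring or the methyl group carries the step, a question that the unsubstituted pyrrolidin-1-yl group would address, and whether a piperidin-1-yl or morpholin-4-yl group would behave in the same way. They also leave open whether the same exchange would give a step of similar size on a core carrying a further chloro group, as compound 2 does.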